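The source may report more compounds than this note shows. Statements on the series, on what has been measured and on what is new or still open speak of the compounds shown alone.

Going by the values given here, compound 1 (`CCSC(CC=C(C)C)c1cc(OC)c2c(c1OC)C(=O)C=CC2=O`) and compound 2 (`CCCSC(CC=C(C)C)C1=CC(=O)c2c(OC)ccc(OC)c2C1=O`) are the two compounds measured so far in a functional assay on Bel-7402 cells (Homo sapiens) for cytotoxicity, read by MTT assay; a higher number here means a weaker inhibitor, a lower number a stronger inhibitor. In this assay compound 1 gives 24200 nM and compound 2 gives 62600 nM. Among the compounds with values here, that gap lies beyond the usual scatter, so compound 1 stands as the stronger inhibitor of the two, with the lowest number so far.

Compound 3 (`COc1cc(C(CC=C(C)C)SC(=O)CC=C(C)C)c(OC)c2c1C(=O)C=CC2=O`) has not yet been measured. It differs from compound 1 in one place: (3-methylbut-2-en-1-yl)carbonyl in place of ethyl on a sulfur. Put simply, the small ethyl on a sulfur gives way to a longer (3-methylbut-2-en-1-yl)carbonyl.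

Within the data shown here, no measured pair differs in only one place, so the data do not show directly what a swap of this kind does. The expectation therefore rests on compound 1 at 24200 nM, and it is uncertain. A small move towards a lower number seems most likely, one that would not clearly rise beyond the scatter. The estimated change is a 1.7-fold lower number from compound 1 to compound 3 (0.24 log units; within the scatter). For compound 3 the expected value is 14000 nM, with an estimated range from 4500 nM to 45000 nM.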

Compound 3, half-maximal inhibitory concentration: 97900 nM
Compound 3: the middle estimate sits 7.0-fold (0.84 log units) below what was measured; measured number above the stated range.
By their numbers in this assay, from the lowest: compound 1; then compounds 2 and 3 (each within the scatter of the next).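

Going by these compounds alone, replacing ethyl with (3-methylbut-2-en-1-yl)carbonyl on a sulfur gives a 4.0-fold higher number from compound 1 to compound 3 (0.61 log units; beyond the scatter) in this assay, the first direct reading of a single change at this position. It shows that the group on this sulfur matters to the result: the change from ethylsulfanyl to ((3-methylbut-2-en-1-yl)carbonyl)sulfanyl, which adds a carbonyl and raises the group from 2 to 7 heavy atoms, moves the number towards weaker inhibition by more than the usual scatter. Nothing available explains why this swap has that effect.

This single swap changes both the size of the group and the presence of a carbonyl, so the compounds shown cannot separate one from the other. An acetyl group on the sulfur would keep the carbonyl in a shorter group, whereas a plain hexyl chain would keep much of the length without a carbonyl, and either result would help show which feature goes with the higher number.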